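The source may report more compounds than this note shows. Statements on the series, on what has been measured and on what is new or still open speak of the compounds shown alone.

Compound 1 `CCC(C)C1NC(=O)N(C2CCCC2)C1=O` and compound 2 `CC(C)C1NC(=O)N(C2CCCC2)C1=O` share one core and differ only in a side chain on it. In a functional assay on WI-38 cells (Homo sapiens) for inhibition (a higher number here means a weaker inhibitor, a lower number a stronger inhibitor), compound 1 gives > 100000 nM, which is a limit of the assay rather than a number. In this assay compound 2 likewise gives > 100000 nM, again a limit. Compound 2 therefore stands at that limit, and the step that the two limits leave unreadable from compound 1 to compound 2 cannot be read, since (the limit of > 100000 nM in this assay, at which 2 of the 2 values shown sit).

Compound 3 `O=C1NC(c2ccccc2)C(=O)N1C1CCCC1` is not yet measured. It differs from compound 2 by phenyl in place of isopropyl on a saturated ring carbon. Within the data shown here, no measured step touches this position, and the one measured step, a step that the two limits leave unreadable from compound 1 to compound 2, gives no readable size. On that basis the expected step of a number no higher from compound 2 to compound 3 (the limit leaves the size open) is none that can be foreseen beyond the scatter. Compound 3 is therefore estimated at 100000 nM in this assay, within a range from 20000 nM to 500000 nM, with a good chance that only a limit is reported.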

Compound 3, half-maximal inhibitory concentration: > 100000 nM
Compound 3 gave a limit, no number (the forecaster's own chance of this, stated with the estimate: 80%); the middle value lies on the limit itself.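

No step can be read among compound 1, compound 2 and compound 3, since each gives only a limit of the assay and no number: the limit of > 100000 nM in this assay, at which 3 of the 3 values shown sit.

The compounds shown leave open whether any group at this position on the shared core gives a readable inhibition in this assay, and how sec-butyl, isopropyl and phenyl would then compare.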